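Thioester variation on the six-carbon chain of the pyrazole amide series

A few compounds are considered here, and "the series" means these few. Any claim that something is new, unique, unknown or untested is made for them only; others in the source may bear on it.

Two compounds in this set have numbers. The symmetric disulfide compound 1 `O=C(NCCCCCCSSCCCCCCNC(=O)c1cc(-c2ccncc2)n[nH]1)c1cc(-c2ccncc2)n[nH]1` gives 6920 nM in a functional assay on HT-29 cells (Homo sapiens) for inhibition, read by MTT assay, with a stated time of 96 h; on this read-out higher numbers stand for weaker inhibition of growth and lower numbers for stronger inhibition of growth. The benzyl thiocarbonate compound 2 `O=C(OCc1ccccc1)SCCCCCCNC(=O)c1cc(-c2ccncc2)n[nH]1` gives 22000 nM in this assay, the higher of the two numbers, and the gap between compound 1 and compound 2 lies beyond the usual scatter, so compound 2 is the weaker growth inhibitor of the pair.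

The next compound, compound 3 `CC(C)C(=O)SCCCCCCNC(=O)c1cc(-c2ccncc2)n[nH]1`, keeps the shared core and the six-carbon chain of compound 2 and changes only the group on the thioester carbonyl carbon: isopropyl in place of benzyloxy on a carbonyl carbon. Going by the values given here, no measured pair in the set shows what such a swap does here, so there is nothing to lean on beyond the two numbers. The step from compound 2 to compound 3 in this assay is expected to be small, with no clear direction, a 1.1-fold lower number from compound 2 to compound 3 (0.04 log units; within the scatter). Compound 3 is accordingly estimated at 20000 nM in this assay, within a range of 7000 nM to 55000 nM.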

Compound 3, concentration for 50% growth inhibition: 25700 nM
Estimate against measurement, compound 3: 1.3-fold (0.11 log units) below, within the range that was stated.
By their numbers in this assay, from the lowest: compound 1; then compounds 2 and 3 (each within the scatter of the next).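

In this assay the change of benzyloxy to isopropyl on a carbonyl carbon whose other neighbour is sulfur gives a 1.2-fold higher number from compound 2 to compound 3 (0.07 log units; within the scatter) and so does not separate the two compounds. Going from 8 heavy atoms to 3, and losing the six-membered aromatic ring and the hydrogen-bond acceptor of benzyloxy, therefore leaves the read-out in the same place, so neither that ring nor that oxygen is needed to hold the level of compound 2. No measurement at hand accounts for this result.

Still open, on these data alone, is whether a different group on this carbonyl carbon, such as an amine or a carboxylic acid, would give a step beyond the scatter. Also open, as far as these compounds go, is what a free thiol or a longer chain would do in place of the thioester on the six-carbon chain.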